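From compound 1 to compound 4: a larger side group

The source may hold more compounds than are shown below. What is called first, only, known or untested is meant among the compounds shown, and "the series" means these compounds.

Measured so far:
compound 1 `C=C(Br)C(=O)Nc1cccc(-c2cn3nc(-c4ccccc4)sc3n2)c1` gives 1400 nM in a functional assay on HeLa cells (Homo sapiens) for inhibition, read by cell counting, with a stated time of 4 days; on this read-out lower numbers stand for stronger inhibition and higher numbers for weaker inhibition
compound 2 `Nc1cccc(-c2cn3nc(CCc4ccccc4)sc3n2)c1` gives 242000 nM in this assay
compound 3 `Nc1cccc(-c2cn3nc(-c4ccccc4)sc3n2)c1` gives 26000 nM in this assay

Compound 1 has the lowest number of the three, so it stands as the strongest inhibitor here; its nearest neighbour is compound 3, and compound 2 lies furthest away. Among the compounds with values here, the only single step among the measured compounds, a 19-fold higher number from compound 1 to compound 3 (1.27 log units; beyond the scatter), shows how much the (1-bromoethenyl)carbonyl group on the nitrogen matters; compound 4 keeps that group, so this step does not predict its behaviour directly.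

Compound 4 `C=C(Br)C(=O)Nc1cccc(-c2cn3nc(Cc4ccc(OC)cc4)sc3n2)c1` differs from compound 1 at the other end of the shared core: 4-methoxybenzyl in place of phenyl on an aromatic carbon. Within the data shown here, no measured pair isolates this exact change. The closest hint comes from compound 2 and compound 3, which differ by a chain-extended aromatic group in place of phenyl at the same place; compound 2 at 242000 nM is clearly weaker than compound 3 at 26000 nM. On these data alone, a group placed on a one-carbon linker is a smaller departure than that, and the methoxy adds an acceptor whose effect is unknown. Compound 4 is therefore expected to be weaker than compound 1, by a step of a 4.3-fold higher number from compound 1 to compound 4 (0.63 log units; beyond the scatter), giving an estimated 6000 nM with a range from 1500 nM to 25000 nM.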

Compound 4, half-maximal inhibitory concentration: 2300 nM
Compound 4: the middle estimate sits 2.6-fold (0.42 log units) above what was measured; low and high end bracket the measured number.
By their numbers in this assay, from the lowest: compounds 1 and 4 (each within the scatter of the next); then compound 3; then compound 2.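

In this assay, putting 4-methoxybenzyl in place of phenyl gives a 1.6-fold higher number from compound 1 to compound 4 (0.22 log units; within the scatter), so the two compounds cannot be told apart on this read-out. With the (1-bromoethenyl)carbonyl group kept on the nitrogen, this aromatic carbon next to the ring nitrogen and next to the ring sulfur can therefore carry a group of 9 heavy atoms instead of one of 6, including an oxygen and a one-carbon link to the ring, while the number stays within the usual scatter of that of compound 1. No evidence is available on why the number holds across this change.

The compounds shown do not separate the two parts of the change, since plain benzyl would carry the one-carbon link without the methoxy, and 4-methoxyphenyl would carry the methoxy without the link. Also open, on these data alone, is how other groups at this place would read out with the (1-bromoethenyl)carbonyl group kept, such as a phenyl ring bearing an amine or a carboxylic acid, or a longer chain ending in a phenyl ring.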